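The compounds below may be only part of what the source reports. "The series", "measured", "known", "first", "only" and "open" are said of these compounds alone.

Measured so far in a functional assay on NCI-H460 cells (Homo sapiens) for cytotoxicity, read by MTT assay, with a stated time of 72 h; a higher number here means a weaker inhibitor, a lower number a stronger inhibitor:

Compound 1 `CNC1=CC(=O)C=C(C(C)(C)C)C1=O` gives 25000 nM
Compound 2 `CC(C)(C)C1=CC(=O)C=CC1=O` gives > 100000 nM (a limit of the assay, not a number)
Compound 3 `CCNC1=CC(=O)C=C(C(C)(C)C)C1=O` gives 13000 nM

Compound 2 stands at the limit of > 100000 nM in this assay, at which 1 of the 3 values shown sits. It therefore offers only a limit as a starting point, not a true number.

Compound 4 `CCNC1=CC(=O)C(C(C)(C)C)=CC1=O` has not yet been measured. Its structure departs from that of compound 2 as follows: ethylamino in place of hydrogen on a double-bonded ring carbon. In words, ethylamino takes the place of hydrogen on a double-bonded ring carbon, three ring bonds from the ring atom that bears a tert-butyl group.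

Going by the values given here, two measured steps bear most directly on this change. Placing the same ethylamino group on another ring carbon gave an at least 7.6-fold lower number from compound 2 to compound 3 (0.88 log units; beyond the scatter). Removing a methylamino group pointed the same way, with an at least 4.0-fold higher number from compound 1 to compound 2 (0.60 log units; beyond the scatter). The length of the chain on the nitrogen made no clear difference, with a 1.9-fold lower number from compound 1 to compound 3 (0.28 log units; within the scatter). Among the compounds with values here, no measured compound carries its amino group at the place it occupies in compound 4, so the expectation stays broad.

The expected change is an at least 6.6-fold lower number from compound 2 to compound 4 (0.82 log units; beyond the scatter), a move towards a stronger inhibitor. The estimate for compound 4 is 15000 nM, with an expected range from 5000 nM to 50000 nM.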

Compound 4, half-maximal inhibitory concentration: 64000 nM
Beside the measured number, compound 4's estimate is 4.3-fold (0.63 log units) below it; the whole stated range lies below it.
By their numbers in this assay, from the lowest: compounds 3 and 1 (each within the scatter of the next); then compound 4. At a limit, above all of these: compound 2.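

In this assay, placing ethylamino on this double-bonded ring carbon, three ring bonds from the ring atom that bears a tert-butyl group, gives an at least 1.5-fold lower number from compound 2 to compound 4 (0.19 log units; that floor lies within the scatter), so this change is not shown to do more than the scatter of the assay allows. On these data alone, the true size of the step stays unknown, as compound 2 offers only a limit and not a number: the limit of > 100000 nM in this assay, at which 1 of the 4 values shown sits. Going by these compounds alone, the place of the group matters more than the earlier compounds could show: compound 3, which carries the same ethylamino group on another ring carbon, gives 13000 nM, whereas compound 4 gives 64000 nM, a clearly higher number in the printed values.

The compounds shown leave open whether a plain amino group, a methylamino group or a longer chain such as butylamino at this same place would behave like ethylamino, or whether the higher number holds for every amine here. They also leave open how far ethylamino truly moves the number at this place, since that depends on a real value for compound 2, which the limit does not give.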